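A few compounds are considered here, and "the series" means these few. Any claim that something is new, unique, unknown or untested is made for them only; others in the source may bear on it.

Compound 1 `Nc1nc(O)c2c(n1)n(C1OC(CO)[C@@H](O)[C@H]1O)c(=O)n2CC(O)CSc1ccccc1` is one of three compounds that have been tested in a functional assay on the whole organism (B cells) with Mus musculus as the target; a higher number here means a larger maximal response, a lower number a smaller maximal response. In this assay compound 1 gives 12%. Among the three numbers that stands second highest: compound 2 `C=CCN1C(=C(C(=O)OCC)C(=O)OCC)N([C@H]2OC(CO)[C@H]3OC(C)(C)O[C@H]32)c2cc(N)nc(O)c21` gives 0%, a number lower by a step beyond the scatter, and compound 3 `C=CCn1c(=O)n(C2C[C@H](O)C(CO)O2)c2nc(N)nc(O)c21` gives 99%, a number far higher, again beyond the scatter. Compound 1 thus sits much nearer to the bottom than to the top of what has been seen so far.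

Compound 4 `Cn1c(=O)n(C2OC(CO)[C@@H](O)[C@H]2O)c2nc(N)nc(O)c21` has not yet been measured in this assay. It differs from compound 1 in one place: hydrogen in place of 1-hydroxy-2-(phenylsulfanyl)ethyl on a saturated chain carbon bound to an aromatic nitrogen. The shared core and the sugar are kept.

Among the measured compounds shown here, no two measured compounds differ in only this one place, so no step of this kind is known. Compound 3, which carries a small group on the same kind of aromatic nitrogen and gives 99%, suggests that a smaller group at this place may go with a larger maximal response, but its sugar also differs, so the step from compound 1 to compound 4 is expected to be upward and sizeable, a number 43 percentage points higher from compound 1 to compound 4 (beyond the scatter), with wide uncertainty. Compound 4 is therefore estimated at 55%, within a range from 15% to 100%.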

Compound 4, largest response reached (reported as maximal response), in percent of the reference or control that the assay uses: 99%
Compound 4: middle estimate off by 44 percentage points, on the low side; low and high end bracket the measured number.
By their numbers in this assay, from the lowest: compound 2; then compound 1; then compounds 3 and 4 (each within the scatter of the next).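

In this assay, among the compounds shown here, the exchange of 1-hydroxy-2-(phenylsulfanyl)ethyl for hydrogen on a saturated chain carbon bound to an aromatic nitrogen gives a number 87 percentage points higher from compound 1 to compound 4 (beyond the scatter) and is the first step at this place in which nothing else changes. With the shared core and the sugar kept, this one change separates a low maximal response from a high one, which compound 3 could not show, as its sugar also differs from that of compound 1. No measurement shown here offers an explanation for the size of this step.

The compounds shown leave open which part of the departing group, the phenyl ring, the sulfur or the hydroxyl, goes with the low response. They also leave open how a longer alkyl chain, an amine or a carboxylic acid at this place would fall in this range.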